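Methyl in Place of Chloro on the Fused Core

A few compounds are considered here, and "the series" means these few. Any claim that something is new, unique, unknown or untested is made for them only; others in the source may bear on it.

compound 1 `O=C(CCCc1ccccc1)Nc1nc2ccc(Cl)cc2c(=O)s1`: > 1000 nM
compound 2 `O=C(CCCc1ccccc1)Nc1nc2sccc2c(=O)s1`: 361 nM
compound 3 `O=C(CCc1ccccc1F)Nc1nc2ccccc2c(=O)s1`: 801 nM

Of the compounds shown here, three have been measured in an assay on CHO cells for displacement of a labelled ligand from adenosine receptor A2b (Homo sapiens), read by scintillation counting, with a stated time of 75 min; on this read-out higher numbers stand for weaker inhibition and lower numbers for stronger inhibition. Compound 1 `O=C(CCCc1ccccc1)Nc1nc2ccc(Cl)cc2c(=O)s1` gives > 1000 nM, which is a limit of the assay and not a number. In this assay compound 2 `O=C(CCCc1ccccc1)Nc1nc2sccc2c(=O)s1` gives 361 nM, and compound 3 `O=C(CCc1ccccc1F)Nc1nc2ccccc2c(=O)s1` gives 801 nM. Compound 1 thus sits at the limit of > 1000 nM in this assay, at which 1 of the 3 values shown sits, and how far it lies from compound 2 or compound 3 cannot be told from these figures. The unmeasured compound 4 `Cc1ccc2nc(NC(=O)CCCc3ccccc3)sc(=O)c2c1` differs from compound 1 by methyl in place of chloro on an aromatic carbon. Among the compounds with values here, no measured pair shows this change, so its effect has not been observed. A step in this assay of modest size is expected, in either direction, and it may well stay within the scatter of the method. Compound 4 is estimated at 900 nM, with a range from 300 nM to 3000 nM. The expected step is an at least 1.1-fold lower number from compound 1 to compound 4 (0.04 log units; that floor lies within the scatter).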

Compound 4, inhibition constant: 408 nM
Beside the measured number, compound 4's estimate is 2.2-fold (0.34 log units) above it; the range from low to high includes it.
By their numbers in this assay, from the lowest: compounds 2, 4 and 3 (each within the scatter of the next, the first and the last beyond it). At a limit, above all of these: compound 1.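

In this assay, within the data shown here, methyl in place of chloro on an aromatic carbon of the shared core gives an at least 2.4-fold lower number from compound 1 to compound 4 (0.38 log units; beyond the scatter), which shows for the first time that this position responds to this change by more than the scatter of the method. Compound 1 gives > 1000 nM, which is a limit of the assay and not a number. The step is therefore only a floor and its true size cannot be read, because it starts from that limit: the limit of > 1000 nM in this assay, at which 1 of the 4 values shown sits.

The compounds shown leave open how fluoro, methoxy or an amine on the same aromatic carbon would compare with methyl and chloro. Going by these compounds, the change also rests on this single pair, so whether it would act alike with a different chain on the amide remains unknown.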